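The source may report more compounds than this note shows. Statements on the series, on what has been measured and on what is new or still open speak of the compounds shown alone.

Measured so far:
compound 1, `NC(N)=NC(=O)c1nc(Cl)c(NC2CC2)nc1N`, 78%
compound 2, `NC(N)=NC(=O)c1nc(Cl)c(NCC2CCCCC2)nc1N`, 96%

Both compounds were tested in an assay for inhibition of acid-sensing ion channel 3 (Homo sapiens), read by patch clamp, tested at 20 uM; on this read-out lower numbers stand for less inhibition and higher numbers for more inhibition at the one concentration tested (going by the name of the read-out). Compound 2 stands highest of the two numbers; its nearest neighbour is compound 1, and the step of a number 18 percentage points higher from compound 1 to compound 2 (beyond the scatter) lies beyond the scatter, so compound 2 is the more inhibiting of the two measured compounds.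

Compound 3, `NC(N)=NC(=O)c1nc(Cl)c(Nc2cccc(Cl)c2)nc1N`, is not yet measured. It differs from compound 2 in one place: 3-chlorophenyl in place of cyclohexylmethyl on a nitrogen on an aromatic ring.

Among the measured compounds shown here, only one measured step bears on this place, the step from cyclopropyl to cyclohexylmethyl on the same nitrogen, a number 18 percentage points higher from compound 1 to compound 2 (beyond the scatter), which was modest. For the measured compounds named here, no measured step shows an aromatic group on this nitrogen, so the direction for an aromatic replacement is not known from the data. Compound 2 already sits near the top of the scale, which leaves more room downward than upward. Compound 3 is therefore expected to stay strongly inhibiting, with a step of a number 11 percentage points lower from compound 2 to compound 3 (beyond the scatter) in this assay, which would be within or just beyond the scatter. The estimate for compound 3 is 85%, with a range from 60% to 98%.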

Compound 3, a percentage reported as inhibition, at one concentration (the size of the read-out at that concentration, not a potency): 94%
Compound 3: the middle estimate sits 9 percentage points below what was measured; measured number inside the range.
By their numbers in this assay, from the lowest: compound 1; then compounds 3 and 2 (each within the scatter of the next).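

In this assay, compound 3 puts an aromatic ring on this nitrogen, and exchanging cyclohexylmethyl for 3-chlorophenyl, a group with the same count of heavy atoms, gives a number 2 percentage points lower from compound 2 to compound 3 (within the scatter). The nitrogen on the aromatic ring therefore carries either a non-aromatic carbon ring on a one-carbon link or a chlorine-bearing aromatic ring with no difference that this read-out can separate, and the comparison with the smaller group shows a number 16 percentage points higher from compound 1 to compound 3 (beyond the scatter) alongside a number 18 percentage points higher from compound 1 to compound 2 (beyond the scatter). Nothing available here explains why these two groups read alike.

Compound 2 and compound 3 both lie close to the top of the scale at a single concentration, so the read-out leaves open whether they would differ in potency across a range of concentrations. On these data alone, it also remains unknown whether the chlorine of compound 3 matters, which a plain phenyl group on this nitrogen would address, and how a carboxylic acid or an amine on that ring would read.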